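A few compounds are considered here, and "the series" means these few. Any claim that something is new, unique, unknown or untested is made for them only; others in the source may bear on it.

Series notes. Compound 1 `C=C(C)c1cn(-c2cccc(C(=O)/C=C/c3ccc(O)c(OC)c3)c2)nn1` bears 1-methylethenyl; in a functional assay on RAW264.7 cells (Mus musculus) for inhibition, with a stated time of 4 days (a higher number here means a weaker inhibitor, a lower number a stronger inhibitor), compound 1 gives 9790 nM. Compound 2 `C=C(C)c1cn(-c2cccc(C(=O)/C=C/c3ccc(OC)c(O)c3)c2)nn1` differs from it in one place, and in this assay compound 2 gives 7760 nM. For the measured compounds named here, the only measured step, a 1.3-fold lower number from compound 1 to compound 2 (0.10 log units; within the scatter), lies within the scatter. Going by the values given here, compound 2 therefore holds the lowest of the two numbers so far, but its gap to compound 1 is within the scatter, so no order between them can be read.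

Compound 3 `COc1ccc(-c2cn(-c3cccc(C(=O)/C=C/c4ccc(OC)c(O)c4)c3)nn2)cc1` is the next step from compound 2: 4-methoxyphenyl in place of 1-methylethenyl on an aromatic carbon. Among the compounds with values here, no measured step bears on this change; the single step measured so far alters a different part of the molecule and says nothing about this one. Without a precedent, no step beyond the scatter is expected in this assay, and the expected step is a 1.2-fold lower number from compound 2 to compound 3 (0.08 log units; within the scatter). Compound 3 is accordingly estimated at 6500 nM, with a wide range of 2500 nM to 17000 nM reflecting the absence of any relevant measurement.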

Compound 3, half-maximal inhibitory concentration: 6290 nM
Estimate against measurement, compound 3: 1.0-fold (0.01 log units) above; low and high end bracket the measured number.
By their numbers in this assay, from the lowest: compounds 3, 2 and 1 (each within the scatter of the next).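

On the aromatic carbon of the five-membered aromatic ring with 3 nitrogen, 4-methoxyphenyl in place of 1-methylethenyl reads in this assay as a 1.2-fold lower number from compound 2 to compound 3 (0.09 log units; within the scatter), so this change gives no order between the two compounds. For the compounds shown here, it is the first measured change at this position, and it shows that a group of 8 heavy atoms with a six-membered aromatic ring can replace one of 3 heavy atoms with no ring without a step beyond the scatter. No available evidence accounts for this result.

From the compounds shown here alone, whether any group at this position can move the number beyond the scatter remains open, for example an amine, a carboxylic acid or a longer chain. Also open, going by these compounds, is whether unsubstituted phenyl would read the same as 4-methoxyphenyl here.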